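The source may report more compounds than this note shows. Statements on the series, on what has been measured and on what is new or still open speak of the compounds shown alone.

Working notes on the series sharing the core of compound 1 `CCn1c(C(=O)N(CCC#N)CCC#N)ccc1C(CC)(CC)c1ccc(OCCC(O)(CC)CC)c(C)c1`. Among the compounds with values here, in an ADME assay on L02 cells (Homo sapiens) for antiproliferative activity, read by MTT assay, with a stated time of 48 h (on this read-out higher numbers stand for weaker inhibition and lower numbers for stronger inhibition), compound 1 gives 37800 nM, the highest of the three numbers measured so far. Compound 2 `CCC(C)C(NC(=O)c1ccc(C(CC)(CC)c2ccc(OCCC(O)(CC)CC)c(C)c2)n1CC)C(=O)O` gives 9990 nM in this assay, the step being a 3.8-fold lower number from compound 1 to compound 2 (0.58 log units; beyond the scatter). Compound 3 `CCn1c(C(=O)N(C)CCO)ccc1C(CC)(CC)c1ccc(OCCC(O)(CC)CC)c(C)c1` gives 2050 nM, the step being an 18-fold lower number from compound 1 to compound 3 (1.27 log units; beyond the scatter); between these two there is a 4.9-fold lower number from compound 2 to compound 3 (0.69 log units; beyond the scatter). Compound 4 `CCn1c(C(=O)NC(CO)CCO)ccc1C(CC)(CC)c1ccc(OCCC(O)(CC)CC)c(C)c1` differs from compound 1 in one place: a group of 7 heavy atoms (4 carbon, 1 nitrogen, 2 oxygen; no ring) in place of a group of 9 heavy atoms (6 carbon, 3 nitrogen; no ring), on a carbonyl carbon. Both measured replacements on this carbonyl carbon lowered the number, the larger one with an entering group that carries oxygen, so a downward step is expected for compound 4, estimated as an 8.4-fold lower number from compound 1 to compound 4 (0.92 log units; beyond the scatter). Compound 4 is therefore expected to give 4500 nM, within 1500 nM to 13000 nM.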

Compound 4, half-maximal inhibitory concentration: 3040 nM
Estimate against measurement, compound 4: 1.5-fold (0.17 log units) above; measured number inside the range.
By their numbers in this assay, from the lowest: compounds 3 and 4 (each within the scatter of the next); then compound 2; then compound 1.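

In this assay, 3-hydroxy-1-(hydroxymethyl)propyl on the amide-type nitrogen gives a 12-fold lower number from compound 1 to compound 4 (1.09 log units; beyond the scatter) as a large step, so the large drop from compound 1 is no longer confined to the (2-hydroxyethyl)(methyl)amino group of compound 3. The two hydroxyl-bearing groups cannot be separated, with a 1.5-fold higher number from compound 3 to compound 4 (0.17 log units; within the scatter) inside the scatter. Both lie beyond the scatter from the carboxylic acid of compound 2, with a 3.3-fold lower number from compound 2 to compound 4 (0.52 log units; beyond the scatter) for this new group.

From the compounds shown here alone, whether an amine or a longer hydroxyalkyl chain on this carbonyl carbon would fall with these two groups remains open. No evidence is available to explain these differences.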